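This account rests on a few compounds, and the source may have more. Where it says the series, first, only, none or still open, it means among the compounds named here.

Compound 1 `O=C(Nc1cccc(-n2cc(-c3ccncc3)c(-c3cc(O)cc(Cl)c3)n2)c1)Nc1ccc(Cl)c(C(F)(F)F)c1` gives -73% in a functional assay on UO-31 cells (Homo sapiens) for inhibition, read by sulforhodamine B assay, with a stated time of 48 h, tested at 100 uM (on this read-out lower numbers stand for a stronger effect and higher numbers for a weaker effect at the one concentration tested), the lowest of the two numbers recorded here. Compound 2 `O=C(Nc1cccc(-n2cc(-c3ccncc3)c(-c3cc(O)cc(Cl)c3)n2)c1)Nc1ccc(Cl)c(Cl)c1` gives -27% in this assay, and the step of a number 46 percentage points higher from compound 1 to compound 2 (beyond the scatter) came with chloro in place of trifluoromethyl on an aromatic carbon. Compound 3 `COc1cc(Cl)cc(-c2nn(-c3cccc(NC(=O)Nc4ccc(Cl)c(C(F)(F)F)c4)c3)cc2-c2ccncc2)c1` differs from compound 1 by methyl in place of hydrogen on an oxygen on an aromatic ring. Among the compounds with values here, no measured step touches this kind of change, so the data give no guide to how large a step to expect in this assay or in which direction. Compound 3 is therefore estimated at -55%, within a range from -90% to -10%, an expected step of a number 18 percentage points higher from compound 1 to compound 3 (beyond the scatter).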

Compound 3, a percentage reported as activity, at one concentration (the size of the read-out at that concentration, not a potency): -50%
Beside the measured number, compound 3's estimate is 5 percentage points below it, within the range that was stated.
By their numbers in this assay, from the lowest: compound 1; then compound 3; then compound 2.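

In this assay, changing hydroxy to methoxy on the 3-chloro-5-hydroxyphenyl group gives a number 23 percentage points higher from compound 1 to compound 3 (beyond the scatter), so this oxygen's hydrogen does matter to the read-out. The change costs only part of the effect, as compound 3 still gives -50% at the one concentration tested. No supporting measurement bears on why this step occurs. Still open, as far as these compounds go, is how a longer chain on this oxygen, such as ethyl or propyl, or an amine in place of the hydroxy, would read. Also open, from the compounds shown here alone, is whether methoxy would give a similar step on compound 2.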